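From Methyl to Trifluoromethyl: A Small Expected Step

A few compounds are considered here, and "the series" means these few. Any claim that something is new, unique, unknown or untested is made for them only; others in the source may bear on it.

In a functional assay on U-87MG ATCC cells for inhibition, with U-87 MG (Homo sapiens) as the target, read by MTT assay, with a stated time of 72 h (a lower number here means a stronger inhibitor, a higher number a weaker inhibitor), compound 1 `COc1ccccc1-c1csc2cnc(Nc3ccc(C(=O)NC4CCNCC4)c(C)c3)nc12` gives 460 nM and compound 2 `COc1ccccc1-c1csc2cnc(Nc3ccc(C(=O)NC4CCNCC4)cc3C)nc12` gives 250 nM on the same core. These two numbers lie within the usual scatter of each other, so compound 2 stands level with compound 1 on the evidence so far. Compound 3 `COc1ccccc1-c1csc2cnc(Nc3ccc(C(=O)NC4CCNCC4)cc3C(F)(F)F)nc12` differs from compound 2 by a single change trifluoromethyl in place of methyl on an aromatic carbon in which trifluoromethyl stands in place of methyl on an aromatic carbon, ortho to a large group. Within the data shown here, no measured pair of compounds shows a change of this kind, so the expectation is uncertain. In this assay the expected step of a 1.4-fold higher number from compound 2 to compound 3 (0.15 log units; within the scatter) is small, towards a higher number if it has any direction, and it may stay within the scatter. For compound 3 the estimate is 350 nM (expected range 120 nM to 1000 nM).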

Compound 3, half-maximal inhibitory concentration: 2090 nM
Beside the measured number, compound 3's estimate is 6.0-fold (0.78 log units) below it; the measured number lies above the stated range.
By their numbers in this assay, from the lowest: compounds 2 and 1 (each within the scatter of the next); then compound 3.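

In this assay, the step of an 8.4-fold higher number from compound 2 to compound 3 (0.92 log units; beyond the scatter) shows that this aromatic carbon, ortho to a large group, does not accept every small substituent equally: trifluoromethyl in place of methyl moves the number clearly upwards. Compounds 1 and 2, whose values lie within the scatter of each other, had shown only methyl on the ring and so gave no sign that a change of substituent here could matter. Nothing measured alongside these numbers accounts for the step, so its cause remains unknown.

The compounds shown leave open whether the step follows from trifluoromethyl alone or extends to other replacements for methyl. A chlorine atom, a methoxy group or an ethyl group on this carbon would help to settle how narrow the preference is.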